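A few compounds are considered here, and "the series" means these few. Any claim that something is new, unique, unknown or untested is made for them only; others in the source may bear on it.

Measured so far in a physicochemical assay for lipophilicity, at pH 7.4; a lower number here means a more polar compound, a higher number a more lipophilic compound:

Compound 1 `N#Cc1ccc(O[C@H]2CN(S(=O)(=O)c3ccc(Cl)cc3)C[C@@]2(O)CO)cc1F`: compound 1 gives 4.1
Compound 2 `N#Cc1ccc(O[C@H]2CN(S(=O)(=O)c3ccc(C(F)(F)F)cc3)C[C@@]2(O)CO)cc1F`: compound 2 gives 4.5

Going by the values given here, compound 2 stands highest of the two numbers in this assay; its nearest neighbour is compound 1, and the single measured step, a number 0.40 log units higher from compound 1 to compound 2 (beyond the scatter), lies beyond the scatter. Compound 3 `N#Cc1ccc(O[C@H]2CN(S(=O)(=O)c3ccc(C(F)(F)F)nc3)C[C@@]2(O)CO)cc1F` has not yet been measured. It differs from compound 2 in one place: 6-(trifluoromethyl)pyridin-3-yl in place of 4-(trifluoromethyl)phenyl on a sulfonyl sulfur. The ring that leaves has no hydrogen-bond acceptor, the ring that enters has one. Among the compounds with values here, no measured step covers a change of this kind; the only step in hand, a number 0.40 log units higher from compound 1 to compound 2 (beyond the scatter), concerns a different group and gives no guide here. On the structural change alone, a downward step in this assay is expected for compound 3, of about a number 1.10 log units lower from compound 2 to compound 3 (beyond the scatter). Compound 3 is therefore estimated at 3.4, with a range from 2.9 to 3.9.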

Compound 3, distribution coefficient: 4.2
Compound 3: middle estimate off by 0.80 log units, on the low side; the whole stated range lies below it.
By their numbers in this assay, from the lowest: compounds 1, 3 and 2 (each within the scatter of the next, the first and the last beyond it).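

In this assay, 6-(trifluoromethyl)pyridin-3-yl in place of 4-(trifluoromethyl)phenyl on a sulfonyl sulfur gives a number 0.30 log units lower from compound 2 to compound 3 (within the scatter), so at this position a ring with one hydrogen-bond acceptor cannot be told apart from a ring with none. Going by these compounds alone, the same ring in place of 4-chlorophenyl gives a number 0.10 log units higher from compound 1 to compound 3 (within the scatter), which leaves a number 0.40 log units higher from compound 1 to compound 2 (beyond the scatter) as the only one of the three steps beyond the scatter. Nothing shown here explains why the step from the phenyl ring to the pyridinyl ring is this size.

The compounds shown leave open whether this holds when an amine or a methoxy group takes the place of trifluoromethyl on the 6-(trifluoromethyl)pyridin-3-yl ring. They also leave open how a carboxylic acid on that ring would read in this assay at this position.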